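This account rests on a few compounds, and the source may have more. Where it says the series, first, only, none or still open, it means among the compounds named here.

Measured so far in a functional assay on SMMC-7721 cells (Homo sapiens) for cytotoxicity, read by MTT assay, with a stated time of 4 days; a lower number here means a stronger inhibitor, a higher number a weaker inhibitor:
compound 1, `Cc1c(O)ccc2c1[C@H](Cn1cc(-c3ccc(F)cc3)nn1)[C@@]13CC(=O)[C@@](C)(CC[C@@H]21)C3`: > 20000 nM, a limit.
compound 2, `Cc1ccc(S(=O)(=O)Oc2ccc3c(c2C)[C@H](Cn2cc(-c4ccccn4)nn2)[C@@]24CC(=O)[C@@](C)(CC[C@@H]32)C4)cc1`: > 20000 nM, a limit.

Compound 2 stands at the limit of this assay and gives no number. For the measured compounds named here, compound 1 sits at the same limit (the limit of > 20000 nM in this assay, at which 2 of the 2 values shown sit), so no step between measured compounds can be drawn from the pair. Compound 3, `Cc1c(O)ccc2c1[C@H](Cn1cc(-c3ccccn3)nn1)[C@@]13CC(=O)[C@@](C)(CC[C@@H]21)C3`, differs from compound 2 in one place: hydrogen in place of (4-methylphenyl)sulfonyl on an oxygen on an aromatic ring. Compound 1 already carries hydrogen on the oxygen on the aromatic ring, with a different substituent on the triazole, and sits at the limit. Going by the values given here, no measured step covers this change, so its size cannot be read from the data, and neither value shown points to a direction; no movement beyond the scatter in this assay is expected. Compound 3 is expected to remain at the limit, with an estimate of 30000 nM (range 10000 nM to 100000 nM). The expected step is a step that the limit leaves unreadable from compound 2 to compound 3.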

Compound 3, half-maximal inhibitory concentration: > 20000 nM
Compound 3: only a limit was reported; the forecaster's own chance of this, stated with the estimate: 80%; the middle value lies beyond the limit too.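

No new step can be read from compound 1, compound 2 and compound 3 in this assay, because each gives only a limit: the limit of > 20000 nM in this assay, at which 3 of the 3 values shown sit.

The compounds shown leave open whether hydrogen in place of (4-methylphenyl)sulfonyl, or pyridin-2-yl in place of 4-fluorophenyl, changes cytotoxicity at all.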